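A few compounds are considered here, and "the series" means these few. Any claim that something is new, unique, unknown or untested is made for them only; others in the source may bear on it.

Working notes on the series in an assay on HeLa cells for inhibition of sphingosine-1-phosphate transporter SPNS2 (Mus musculus), read by LC-MS, tested at 2 uM; on this read-out lower numbers stand for less inhibition and higher numbers for more inhibition at the one concentration tested (going by the name of the read-out).

Three compounds carry the shared core with different groups on the saturated chain carbon bound to the aromatic carbon. Compound 1 `CCCCCCCCCCc1ccc(-c2noc(CN)n2)cc1` gives 62% in this assay. Compound 2 `CCCCCCCCCCc1ccc(-c2noc(CCCN(C)C)n2)cc1` gives 8%. Compound 3 `CCCCCCCCCCc1ccc(-c2noc([C@H](N)CCCCN)n2)cc1` gives 50%. On these numbers compound 2 stands lowest: the step is a number 54 percentage points lower from compound 1 to compound 2 (beyond the scatter), and a number 42 percentage points higher from compound 2 to compound 3 (beyond the scatter). The remaining step, a number 12 percentage points lower from compound 1 to compound 3 (beyond the scatter), is modest.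

Compound 4 `CCCCCCCCCCc1ccc(-c2noc(CC(O)CN3CCCC3)n2)cc1` is not yet measured in this assay. It differs from compound 2 as follows: 1-hydroxy-2-(pyrrolidin-1-yl)ethyl in place of 2-(dimethylamino)ethyl on a saturated chain carbon bound to an aromatic carbon. The step bearing most on this change is the large one, a number 54 percentage points lower from compound 1 to compound 2 (beyond the scatter), which shows that lengthening the chain to a dimethylamino group removes most of the inhibition seen in compound 1. The other large step, a number 42 percentage points higher from compound 2 to compound 3 (beyond the scatter), shows that a change in the group on that carbon can bring the number back up. Going by the values given here, compound 4 keeps a chain ending in a tertiary amine but adds a hydroxyl and a five-membered ring; no measured step covers either feature directly. A step upward from compound 2 is therefore expected, but of uncertain size, and is estimated as a number 14 percentage points higher from compound 2 to compound 4 (beyond the scatter). For compound 4 the expected value is 22%, with a range from 0% to 50%.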

Compound 4, a percentage reported as inhibition, at one concentration (the size of the read-out at that concentration, not a potency): 21%
The estimate for compound 4 lay 1 percentage points above the measured number; measured number inside the range.
By their numbers in this assay, from the lowest: compound 2; then compound 4; then compound 3; then compound 1.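

In this assay the move to 1-hydroxy-2-(pyrrolidin-1-yl)ethyl gives a number 13 percentage points higher from compound 2 to compound 4 (beyond the scatter) and so shows that adding a hydroxyl and a five-membered ring to the chain ending in a tertiary amine wins back only a small part of what compound 2 lost. That recovery stays well short of the compounds carrying a primary amine, as a number 29 percentage points lower from compound 3 to compound 4 (beyond the scatter) and a number 41 percentage points lower from compound 1 to compound 4 (beyond the scatter) show, so among these four the two with a primary amine, compound 1 and compound 3, sit higher and the two with a tertiary amine, compound 2 and compound 4, sit lower. Nothing measured here accounts for these differences.

The hydroxyl and the pyrrolidine ring enter together, so the compounds shown cannot assign the step to either one, and a 3-(pyrrolidin-1-yl)propyl group without the hydroxyl or a 3-(dimethylamino)-2-hydroxypropyl group would separate them. Also open, as far as these compounds go, is whether the loss in compound 2 follows the longer chain or the tertiary amine, which a 3-aminopropyl group would test, and how a carboxylic acid on the same chain would read.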